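The compounds below may be only part of what the source reports. "The series", "measured", "known", "first", "only" and "open" are said of these compounds alone.

Measured compounds:
compound 1, `Cc1cc(C(=O)O)nn1Cc1cc(Br)ccc1OCc1ccccc1`, 15.1 nM
compound 2, `Cc1cc(C(=O)O)nn1Cc1cc(Br)ccc1OCc1cccc(Cl)c1`, 427 nM
compound 3, `Cc1cc(C(=O)O)nn1Cc1cc(Cl)ccc1OCc1ccc(Cl)cc1Cl`, 0.55 nM

All three were tested in a functional assay on CHO-K1 cells for antagonist activity at prostaglandin E2 receptor EP1 subtype (Homo sapiens), read by FLIPR; on this read-out lower numbers stand for stronger inhibition and higher numbers for weaker inhibition. Compound 2 gives 427 nM, and compound 1 gives 15.1 nM. The two differ by hydrogen in place of chloro on an aromatic carbon, and this change made a large step, a 28-fold lower number from compound 2 to compound 1 (1.45 log units; beyond the scatter). Compound 3 gives 0.55 nM, the lowest of the three numbers; how its core differs from that of compound 2 is not broken down here, and the two values alone show that compound 3 stands well below compound 2 and also below compound 1 in this assay.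

Compound 4, `Cc1cc(C(=O)O)nn1Cc1ccccc1OCc1ccc(Cl)cc1Cl`, has not yet been measured. It differs from compound 3 by hydrogen in place of chloro on an aromatic carbon. For the measured compounds named here, this is the same kind of change as the one from compound 2 to compound 1, but not the same: in compound 3 the chloro that leaves sits both meta to a large group and para to a large group, whereas in compound 2 it sits meta to a large group only, and on a different ring. Going by the values given here, the earlier step therefore offers a rough guide only, and no measured pair shows the removal of a halogen from the place in question. On that basis the step from compound 3 to compound 4 is expected to be a 5.5-fold higher number from compound 3 to compound 4 (0.74 log units; beyond the scatter), smaller than the earlier one but in the same direction of a weaker result. Compound 4 is thus estimated at 3 nM, with a likely range from 0.7 nM to 15 nM.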

Compound 4, inhibition constant: 8.32 nM
Compound 4: the middle estimate sits 2.8-fold (0.44 log units) below what was measured; the measured number falls inside the stated range.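

In this assay, replacing the chloro of compound 3 with hydrogen gave a 15-fold higher number from compound 3 to compound 4 (1.18 log units; beyond the scatter), so on this core the compound that keeps the chloro, meta to a large group and para to a large group, shows the stronger inhibition. The same kind of change ran in opposite directions on the two cores, and the gap between the two steps lies beyond the scatter: the same change on two cores in this assay, a 28-fold lower number (1.45 log units; beyond the scatter) from compound 2 to compound 1 and a 15-fold higher number (1.18 log units; beyond the scatter) from compound 3 to compound 4, 430-fold (2.63 log units) apart, beyond the scatter of two such steps. This shows that neither the size nor the direction of the step can be carried from one core to another in this series, but it does not show what separates the two results: the chloro leaves a different place on a different ring in each pair, the pairs also differ elsewhere in their structures, and a single pair for each place cannot pull these factors apart.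

As far as these compounds go, it remains open how a chloro at the place it holds in compound 2 would behave on the core of compound 3, and whether a fluoro or a methoxy group at the place of the chloro lost from compound 3 would give a number closer to that of compound 3 or of compound 4. Also open, from the compounds shown here alone, is what an amide would give in place of the carboxylic acid that all four compounds carry.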